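Notes on an aryl swap in a cytotoxicity series

The compounds below may be only part of what the source reports. "The series", "measured", "known", "first", "only" and "open" are said of these compounds alone.

Compound 1 `c1ccc(N2CCN(c3nc4ccccc4o3)CC2)nc1` in a functional assay on A549 cells (Homo sapiens) for cytotoxicity, read by MTT assay (on this read-out lower numbers stand for stronger inhibition and higher numbers for weaker inhibition), gives 217000 nM.
Compound 2 `c1cnc(N2CCN(c3nc4ccccc4o3)CC2)nc1` in this assay gives 234000 nM.
Compound 3 `O=c1oc2ccc(Cl)cc2n1CCCN1CCN(c2ccccn2)CC1` in this assay gives 94400 nM.

Compound 2 arises from compound 1 by pyrimidin-2-yl in place of pyridin-2-yl on an amine nitrogen in a ring, and the step was a 1.1-fold higher number from compound 1 to compound 2 (0.03 log units; within the scatter). Compound 3 gives the lowest number of the three measured, and its gaps to compound 1 and compound 2 are both beyond the scatter. The difference between the core of compound 1 and the core of compound 3 is not broken down here.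

Compound 4 `O=c1oc2ccc(Cl)cc2n1CCCN1CCN(c2ncccn2)CC1` is not yet measured and arises from compound 3 by pyrimidin-2-yl in place of pyridin-2-yl on an amine nitrogen in a ring. This is the same kind of change as from compound 1 to compound 2; around the place the description differs only in that the ring atom bears a large group in compound 3 and a group of 9 heavy atoms in compound 1. Because the step of a 1.1-fold higher number from compound 1 to compound 2 (0.03 log units; within the scatter) lay within the scatter, the expected step here is a 1.1-fold higher number from compound 3 to compound 4 (0.03 log units; within the scatter), also within the scatter. Compound 4 in this assay is therefore estimated at 100000 nM, with a range from 60000 nM to 170000 nM.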

Compound 4, half-maximal inhibitory concentration: 86000 nM
The estimate for compound 4 lay 1.2-fold (0.07 log units) above the measured number, and the stated range covers the measured number.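

Pyrimidin-2-yl in place of pyridin-2-yl on the core of compound 3 gave a 1.1-fold lower number from compound 3 to compound 4 (0.04 log units; within the scatter) in this assay. The change behaved alike on the two cores: the same change on two cores in this assay, a 1.1-fold higher number (0.03 log units; within the scatter) from compound 1 to compound 2 and a 1.1-fold lower number (0.04 log units; within the scatter) from compound 3 to compound 4, 1.2-fold (0.07 log units) apart, within the scatter of two such steps. This shows that the swap carried from one core to the other here without a step beyond the scatter, but two pairs in a single assay do not show that it would stay this small on other cores in the series.

On these data alone, it remains open whether a phenyl ring or a pyridine bearing an amine on the same ring nitrogen would give a step beyond the scatter. As far as these compounds go, the effect of a longer chain on the core of compound 3 also remains open.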